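The source may report more compounds than this note shows. Statements on the series, on what has been measured and on what is new or still open speak of the compounds shown alone.

Among the measured compounds shown here, compound 2 `COc1ccc(C2(NC(=O)CN3CCN(C)CC3)C(=O)Nc3cc(Cl)c(C)cc32)cc1` gives the lowest number of the two measured so far in an in vitro functional assay on CHO-CREluc cells for antagonist activity at growth hormone secretagogue receptor type 1 (Homo sapiens), read by a luciferase reporter, with a stated time of 4 h (a higher number here means a weaker inhibitor, a lower number a stronger inhibitor), with 525 nM; compound 1 `Cc1cc2c(cc1Cl)NC(=O)C2(NC(=O)CN1CCN(C)CC1)c1cccc(Cl)c1` gives 1180 nM, and the step of a 2.2-fold lower number from compound 1 to compound 2 (0.35 log units; beyond the scatter) separates them. Compound 3 `Cc1cc2c(cc1Cl)NC(=O)C2(NC(=O)CN1CCN(C)CC1)c1ccc(Cl)cc1Cl` differs from compound 2 in one place: 2,4-dichlorophenyl in place of 4-methoxyphenyl on a saturated ring carbon. For the measured compounds named here, only one measured step touches the same aryl group, the modest step of a 2.2-fold lower number from compound 1 to compound 2 (0.35 log units; beyond the scatter), in which a chlorine-bearing phenyl gave way to the methoxyphenyl. With two chlorines entering here, a modest rise in number is expected for compound 3: a 1.7-fold higher number from compound 2 to compound 3 (0.23 log units; within the scatter). Compound 3 is estimated at 900 nM, within a range from 300 nM to 2700 nM.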

Compound 3, half-maximal inhibitory concentration: > 10000 nM
Compound 3: a limit, no number (the forecaster's own chance of this, stated with the estimate: 5%); middle value at least 11-fold (1.04 log units) away from the limit.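

On this saturated ring carbon, the choice of aryl group matters far more than the first pair suggested: 2,4-dichlorophenyl gives an at least 19-fold higher number from compound 2 to compound 3 (1.27 log units; beyond the scatter) in this assay, and an at least 8.4-fold higher number from compound 1 to compound 3 (0.92 log units; beyond the scatter). Chlorine alone does not decide the outcome, since compound 1, with 3-chlorophenyl, gives 1180 nM. Compound 3 gives only a limit, not a number: the limit of > 10000 nM in this assay, at which 1 of the 3 values shown sits.

The compounds shown cannot tell which chlorine of 2,4-dichlorophenyl matters, or how far compound 3 lies beyond its limit. As far as these compounds go, how a pyridyl or aminophenyl group would behave at this carbon also remains open.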